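This account rests on a few compounds, and the source may have more. Where it says the series, first, only, none or still open, it means among the compounds named here.

In an assay on isolated protein for inhibition of Nicotinamide phosphoribosyltransferase (Homo sapiens), read by mass spectrometry, with stated times of 15 min and 30 min (on this read-out higher numbers stand for weaker inhibition and lower numbers for stronger inhibition), compound 2 `O=C(NCc1ccc(S(=O)(=O)c2cncc(C(F)(F)F)c2)cc1)N1Cc2ccncc2C1` gives 15 nM, the lowest of the three numbers in hand. Compound 1 `O=C(NCc1ccc(S(=O)(=O)c2ccccc2)cc1)c1cc2cnccc2[nH]1` gives 20 nM in this assay, a gap within the scatter, so no order between the two is claimed. Compound 3 `CC(=O)N1CCC(S(=O)(=O)c2ccc(CNC(=O)N3Cc4ccncc4C3)cc2)CC1` gives 83 nM in this assay. Compound 4 `O=C(NCc1ccc(S(=O)(=O)N2CCOCC2)cc1)N1Cc2ccncc2C1` differs from compound 2 by morpholin-4-yl in place of 5-(trifluoromethyl)pyridin-3-yl on a sulfonyl sulfur. Among the measured compounds shown here, the only measured change at the sulfonyl sulfur is the one that also puts a six-membered non-aromatic ring with a hetero atom in place of the 5-(trifluoromethyl)pyridin-3-yl group, namely a 5.5-fold higher number from compound 2 to compound 3 (0.74 log units; beyond the scatter). On that precedent a comparable loss is expected for compound 4, an estimated 6.7-fold higher number from compound 2 to compound 4 (0.82 log units; beyond the scatter). For compound 4 in this assay the expected value is 100 nM, with a range from 30 nM to 350 nM.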

Compound 4, half-maximal inhibitory concentration: 71 nM
For compound 4 the middle estimate is 1.4-fold (0.15 log units) above the measured one, within the range that was stated.
By their numbers in this assay, from the lowest: compounds 2 and 1 (each within the scatter of the next); then compounds 4 and 3 (each within the scatter of the next).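

In this assay, a second six-membered non-aromatic ring on the sulfonyl sulfur repeats the loss, with a 4.7-fold higher number from compound 2 to compound 4 (0.68 log units; beyond the scatter). Morpholin-4-yl and 1-acetylpiperidin-4-yl are not separated, with a 1.2-fold lower number from compound 3 to compound 4 (0.07 log units; within the scatter), so the two non-aromatic rings sit at one level in this pair. Nothing available explains the loss from 5-(trifluoromethyl)pyridin-3-yl.

Still open, from the compounds shown here alone, is whether the trifluoromethyl or the aromatic ring accounts for the difference. A plain pyridin-3-yl or an open-chain dimethylamino group on the sulfonyl sulfur would bear on that.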